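This account rests on a few compounds, and the source may have more. Where it says the series, first, only, none or still open, it means among the compounds named here.

Of the compounds shown here, two built on a shared core have so far been measured in an assay on isolated protein for inhibition of protein kinase C theta type (Homo sapiens), read by TR-FRET, with a stated time of 2 h; on this read-out higher numbers stand for weaker inhibition and lower numbers for stronger inhibition. Compound 1 `CO[C@H]1CC[C@@H](CNc2cc(NCc3cnccc3C(F)(F)F)ncc2C#N)CC1` gives 70 nM in this assay, the highest of the two numbers. Compound 2 `CC1(C)C[C@H](Nc2cc(NCc3cnccc3C(F)(F)F)ncc2C#N)CC(C)(C)[C@@H]1O`, which carries a different group on the same nitrogen, gives 12 nM in this assay, and the gap between the two lies beyond the usual scatter. Compound 3 `CC1(C)[C@@H](Nc2cc(NCc3cnccc3C(F)(F)F)ncc2C#N)C[C@H]1C(N)=O` has not yet been measured. It differs from compound 1 in one place: 3-carbamoyl-2,2-dimethylcyclobutyl in place of (4-methoxycyclohexyl)methyl on a nitrogen on an aromatic ring. As in compound 2, the entering ring sits directly on the nitrogen and brings one hydrogen-bond donor, while the leaving group had none. Among the compounds with values here, no step between two measured compounds reproduces this exact change, so the expectation rests on compounds 1 and 2 alone. Compound 3 is expected to show a step of a 2.8-fold lower number from compound 1 to compound 3 (0.45 log units; beyond the scatter), toward stronger inhibition, because compound 2 gives 12 nM in this assay with a ring attached in a comparable way. The estimate for compound 3 in this assay is 25 nM, within a range of 8 nM to 80 nM.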

Compound 3, half-maximal inhibitory concentration: 140 nM
The estimate for compound 3 lay 5.6-fold (0.75 log units) below the measured number; measured number above the stated range.
By their numbers in this assay, from the lowest: compound 2; then compounds 1 and 3 (each within the scatter of the next).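

In this assay, replacing (4-methoxycyclohexyl)methyl with 3-carbamoyl-2,2-dimethylcyclobutyl on a nitrogen on an aromatic ring gives a 2.0-fold higher number from compound 1 to compound 3 (0.30 log units; within the scatter), so this position takes a four-membered ring set directly on the nitrogen, with a hydrogen-bond donor, and the number stays within the scatter of the one for the six-membered ring on its methyl link. A ring attached directly to this nitrogen and carrying a donor therefore does not by itself bring a number like that of compound 2 at 12 nM, since compound 3 has both features and gives 140 nM in the same assay. Nothing measured here explains the gap between these two compounds.

The compounds shown do not separate the part played by ring size from that of the group on the ring, as compound 3 differs from compound 2 in both. Also open, on these data alone, is how a hydroxyl on the same 2,2-dimethylcyclobutyl ring would read, or a carboxylic acid or an amine in place of the carbamoyl group.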